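Swapping the Sulfonyl Group on a Fused Ring

This account rests on a few compounds, and the source may have more. Where it says the series, first, only, none or still open, it means among the compounds named here.

Of the compounds shown here, two have been measured so far in an ADME assay on microsomes from liver (Homo sapiens) for metabolic stability, read by LC-MS, using NADPH, with a stated time of 30 min, tested at 1 uM; on this read-out higher numbers stand for fast clearance and lower numbers for slow clearance. Compound 1, with the structure `CC(C)c1noc(N2CCC(Oc3cc(N4CCc5cc(S(C)(=O)=O)ccc54)ncn3)CC2)n1`, gives 69 mL.min-1.g-1 in this assay. Compound 2, with the structure `CCc1cnc(N2CCC(C(C)COC(=O)N3CCc4cc(S(C)(=O)=O)cc(F)c43)CC2)nc1`, gives 329 mL.min-1.g-1. Of the two numbers, that of compound 1 is the lower, and the gap to compound 2 lies beyond the usual scatter, so compound 1 is cleared more slowly than compound 2 in this assay.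

Compound 3, with the structure `CC(C)c1noc(N2CCC(Oc3cc(N4CCc5cc(N6CCOCC6=O)ccc54)ncn3)CC2)n1`, has not yet been measured. It differs from compound 1 in one place: 3-oxomorpholin-4-yl in place of methylsulfonyl on an aromatic carbon. Compound 1 and compound 3 therefore share the same core, and only the group on the aromatic carbon of the fused ring system is exchanged.

Among the measured compounds shown here, no pair of measured compounds shows a single change of this kind, so nothing measured here tells what such an exchange does to clearance. Without that guide, the expected step is a small one: a 1.3-fold higher number from compound 1 to compound 3 (0.12 log units; within the scatter) is estimated to lie within the scatter. Compound 3 is thus expected to give about 90 mL.min-1.g-1 in this assay, with a likely range from 35 mL.min-1.g-1 to 230 mL.min-1.g-1.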

Compound 3, intrinsic clearance in microsomes: 27 mL.min-1.g-1
Compound 3: the middle estimate sits 3.3-fold (0.52 log units) above what was measured; the measured number lies below the stated range.
By their numbers in this assay, from the lowest: compound 3; then compound 1; then compound 2.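

Placing 3-oxomorpholin-4-yl in place of methylsulfonyl on this aromatic carbon of the shared core gives, in this assay, a 2.6-fold lower number from compound 1 to compound 3 (0.41 log units; beyond the scatter) and this modest step is the first single change that can be read here. It shows that methylsulfonyl is not required at this position for a low number on this read-out, and that the position accepts a group with a six-membered non-aromatic ring and 7 heavy atoms in place of one with no ring and 4 heavy atoms, without clearance rising. No measurement at hand bears on the reason for this step.

Still open, from the compounds shown here alone, is which part of the entering group matters: a plain morpholine ring without the carbonyl, an open chain such as a methoxyethyl ether, or a small amine such as dimethylamino could each be set on the same aromatic carbon and compared with compound 3. Among the compounds shown here, also open is whether the same exchange would give a step of similar size on a core other than that of compound 1, since only this one pair shows it.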